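A few compounds are considered here, and "the series" means these few. Any claim that something is new, unique, unknown or untested is made for them only; others in the source may bear on it.

Three compounds share one core and differ only in the group on the saturated chain carbon bound to the carbonyl carbon. Compound 1 `Cn1c(-c2ccc(NC(=O)CSC3=NCCS3)cc2)nc(-c2ccccc2)c1-c1ccccc1` gives 10.3% in a functional assay on MCF7 cells (Homo sapiens) for cytotoxicity, read by MTT assay, with a stated time of 24 h, tested at 0.64 ug/mL; on this read-out lower numbers stand for a weaker effect and higher numbers for a stronger effect at the one concentration tested. Compound 2 `Cn1ccnc1SCC(=O)Nc1ccc(-c2nc(-c3ccccc3)c(-c3ccccc3)n2C)cc1` gives 10.3% in this assay. Compound 3 `CCN1CCN(CC(=O)Nc2ccc(-c3nc(-c4ccccc4)c(-c4ccccc4)n3C)cc2)CC1` gives 4.7% in this assay, the lowest of the three numbers, yet the steps of a number 5.6 percentage points lower from compound 1 to compound 3 (within the scatter) and a number 5.6 percentage points lower from compound 2 to compound 3 (within the scatter) both lie within the scatter, as does no change at the digits printed from compound 1 to compound 2 (within the scatter), so all three read as weak and indistinguishable.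

Compound 4 `Cn1c(-c2ccc(NC(=O)CN3CCN(c4ccccc4)CC3)cc2)nc(-c2ccccc2)c1-c1ccccc1` differs from compound 3 in one place: phenyl in place of ethyl on an amine nitrogen in a ring. Among the measured compounds shown here, no measured step touches the amine nitrogen in the ring of the six-membered non-aromatic ring with 2 nitrogen; the three measured steps each swap the whole group on the chain carbon, and none moved the read-out beyond the scatter. On that basis compound 4 is expected to show no step beyond the scatter, a number 1.3 percentage points higher from compound 3 to compound 4 (within the scatter), so the estimate for compound 4 in this assay is 6%, expected between 0% and 18%.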

Compound 4, a percentage reported as activity, at one concentration (the size of the read-out at that concentration, not a potency): 12.1%
The estimate for compound 4 lay 6.1 percentage points below the measured number; measured number inside the range.
By their numbers in this assay, from the lowest: compounds 3, 1, 2 and 4 (each within the scatter of the next).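

Phenyl in place of ethyl on an amine nitrogen in a ring gives a number 7.4 percentage points higher from compound 3 to compound 4 (within the scatter) in this assay and is the only step here made at that nitrogen, so even a ring of six carbons in place of a two-carbon chain does not separate the two compounds. Swapping the whole group on the chain carbon tells the same story, with a number 1.8 percentage points higher from compound 2 to compound 4 (within the scatter) for 4-phenylpiperazin-1-yl in place of (1-methyl-1H-imidazol-2-yl)sulfanyl and a number 1.8 percentage points higher from compound 1 to compound 4 (within the scatter) for the same group in place of the sulfur-bearing ring group. No separate measurement bears on this result.

From the compounds shown here alone, whether another group on that nitrogen, such as benzyl or acetyl, could move the read-out beyond the scatter stays open. With one concentration per compound, the numbers also give no potency.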